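Carbamoyl-fluorophenyl in place of methylpyrazole on the core

The source may report more compounds than this note shows. Statements on the series, on what has been measured and on what is new or still open speak of the compounds shown alone.

Compound 1 `CCC(c1ccc2ncccc2c1F)n1cnc2ncc(-c3cnn(C)c3)nc21` has in a functional assay on NCI-H1993 cells (Homo sapiens) for inhibition, read by CCK-8 assay, with a stated time of 72 h (on this read-out higher numbers stand for weaker inhibition and lower numbers for stronger inhibition), the entry "not determined" (no result reported); for it no single number stands. Among the compounds with values here, the only measured member of the set is compound 2 `OCCn1cc(-c2cnc3ncn(Cc4ccc5ncccc5c4)c3n2)cn1`, which in this assay gives 2330 nM. Within the data shown here, compound 2 differs from compound 1 in more than one place, so no step between the two is counted and its value serves only as a reference point for what this cell line reads for the shared core.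

Compound 3 `CCC(c1ccc2ncccc2c1F)n1cnc2ncc(-c3ccc(C(N)=O)c(F)c3)nc21` is not yet measured. It keeps the ethyl-bearing linker and the fluoroquinoline of compound 1 and changes one group on the shared core: 4-carbamoyl-3-fluorophenyl in place of 1-methyl-1H-pyrazol-4-yl on an aromatic carbon

With compound 1 unmeasured, no direction for this change can be taken from the data; the replacement is large in count of atoms and swaps two hydrogen-bond acceptors for one donor and one acceptor, so a shift beyond the usual scatter in either direction is possible, and the estimate is held wide.

On the numbers shown, compound 3 is expected to give about 300 nM in this assay, with a range from 50 nM to 2000 nM.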

Compound 3, half-maximal inhibitory concentration: 665 nM
Beside the measured number, compound 3's estimate is 2.2-fold (0.35 log units) below it, within the range that was stated.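

In this assay, within the data shown here, compound 3 gives 665 nM while compound 1 has no single number, so no step between the two can be read. The compounds shown leave open how 4-carbamoyl-3-fluorophenyl in place of 1-methyl-1H-pyrazol-4-yl shifts the read-out on the shared core. No supporting evidence bears on this result.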